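From compound 2 to compound 4: tert-butyl to isopropyl

This account rests on a few compounds, and the source may have more. Where it says the series, first, only, none or still open, it means among the compounds named here.

Compound 1 `COCCOc1ccccc1C1C(C(=O)C(C)(C)C)=C(O)C(=O)N1c1ccc(-c2ccsc2)cc1` gives 22800 nM in a physicochemical assay for solubility, in phosphate buffer, at pH 6.8; on this read-out lower numbers stand for lower solubility and higher numbers for higher solubility
Compound 2 `C[S+]([O-])CCOc1ccccc1C1C(C(=O)C(C)(C)C)=C(O)C(=O)N1c1ccc(-c2ccsc2)cc1` gives > 50000 nM (a limit)
Compound 3 `CN(C)C(=O)COc1ccccc1C1C(C(=O)C(C)(C)C)=C(O)C(=O)N1c1ccc(-c2ccsc2)cc1` gives > 50000 nM (a limit)

Compound 2 reads > 50000 nM as a limit and not a number. This is the limit of > 50000 nM in this assay, at which 2 of the 3 values shown sit.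

Compound 4 `CC(C)C(=O)C1=C(O)C(=O)N(c2ccc(-c3ccsc3)cc2)C1c1ccccc1OCC[S+](C)[O-]` differs from compound 2 by hydrogen in place of methyl on a saturated chain carbon bound to a carbonyl carbon and two saturated chain carbons; tert-butyl becomes isopropyl, hydrogen in place of methyl on a saturated chain carbon bound to a carbonyl carbon and two saturated chain carbons.

The measured steps of an at least 2.1-fold higher number from compound 1 to compound 2 (0.34 log units; beyond the scatter) and an at least 2.1-fold higher number from compound 1 to compound 3 (0.34 log units; beyond the scatter) leave the tert-butyl untouched, as does a step that the two limits leave unreadable from compound 2 to compound 3, so none of them measures this change directly.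

For compound 4 the expected step is a step that the limit leaves unreadable from compound 2 to compound 4, none beyond the scatter in this assay. The estimate for compound 4 is 60000 nM, with an expected range of 25000 nM to 150000 nM, and a reading at the limit is likely.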

Compound 4, solubility: > 50000 nM
Compound 4 was reported as a limit; the forecaster's own chance of this, stated with the estimate: 70%; the middle value does not contradict the limit.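

Among these compounds, compound 2 and compound 4 are both reported as limits in this assay, not as numbers, so no step between them can be read. The compounds shown leave open whether isopropyl in place of tert-butyl shifts this read-out at all.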